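This account rests on a few compounds, and the source may have more. Where it says the series, first, only, none or still open, it means among the compounds named here.

Compound 1 `CNC(=O)c1cc(C(=O)N[C@H]2[C@@H]3COC[C@@H]32)cc2c1OC[C@H]2c1cccnc1`, compound 2 `CNC(=O)c1cc(C(=O)N[C@H]2[C@@H]3COC[C@@H]32)cc2c1OC[C@H]2c1ccc(F)cc1` and compound 3 `CNC(=O)c1cc(C(=O)N[C@H]2[C@@H]3COC[C@@H]32)cc2c1OC[C@H]2C1CCOCC1` share one core and differ only in a single ring substituent. In a physicochemical assay for solubility (on this read-out higher numbers stand for higher solubility and lower numbers for lower solubility), compound 2 gives >= 176 ug/mL, which is a limit and not a number. In this assay compound 1 gives >= 104 ug/mL, which is also a limit. For the measured compounds named here, the position of compound 2 is therefore known only through a limit, and the only other value in the comparison offers no exact reference point.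

Compound 3 carries oxan-4-yl in place of 4-fluorophenyl on a saturated ring carbon. Going by the values given here, the only measured step that bears on this change is at the same position, and it is a step that the two limits leave unreadable from compound 1 to compound 2. It gives no size that can be carried over to the new change and no direction. No step beyond the usual scatter is therefore expected in this assay, in either direction. The expected change is a step that the limit leaves unreadable from compound 2 to compound 3. Compound 3 is estimated at 180 ug/mL, with an expected range from 90 ug/mL to 400 ug/mL.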

Compound 3, solubility: >= 177 ug/mL
Compound 3 was reported as a limit; the forecaster's own chance of this, stated with the estimate: 65%; the middle value lies beyond the limit too.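

In this assay compound 3 gives >= 177 ug/mL, which is a limit. Compound 1 and compound 2 are also reported only as limits, so no step can be read among compound 1, compound 2 and compound 3. The compounds shown leave open where the exact solubility of each lies and whether the ring substituent changes it.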